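Small aromatic changes on a thiosemicarbazone series

The compounds below may be only part of what the source reports. "The series", "measured", "known", "first", "only" and "open" are said of these compounds alone.

- compound 1 `COc1ccc(/C=N\NC(=S)NC(C)(C)CCC[C@](C)(O)[C@@H]2CC=C(C)CC2)cc1` gives 6500 nM
- compound 2 `CC1=CC[C@@H]([C@@](C)(O)CCCC(C)(C)NC(=S)N/N=C\c2ccc(O)cc2)CC1` gives 6230 nM
- compound 3 `CC1=CC[C@@H]([C@@](C)(O)CCCC(C)(C)NC(=S)N/N=C\c2ccc([N+](=O)[O-])cc2)CC1` gives 13400 nM

These three values come from a functional assay on OVCAR-3 cells (Homo sapiens) for cytotoxicity, read by sulforhodamine B assay; a lower number here means a stronger inhibitor of growth, a higher number a weaker inhibitor of growth. Compound 2 gives 6230 nM and has the lowest of the three numbers, though it lies within the scatter of compound 1. The change now followed is 3-chlorophenyl in place of 4-hydroxyphenyl on a carbon with a double bond to nitrogen, which gives compound 4 `CC1=CC[C@@H]([C@@](C)(O)CCCC(C)(C)NC(=S)N/N=C\c2cccc(Cl)c2)CC1`, with 3-chlorophenyl in place of 4-hydroxyphenyl on a carbon with a double bond to nitrogen.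

Going by the values given here, three measured steps bear on this change, all of them swaps of one group on the aromatic ring. They are a 1.0-fold lower number from compound 1 to compound 2 (0.02 log units; within the scatter), a 2.2-fold higher number from compound 2 to compound 3 (0.33 log units; beyond the scatter) and a 2.1-fold higher number from compound 1 to compound 3 (0.31 log units; beyond the scatter). The first is within the scatter and the other two are modest. None of them involves chlorine, so they offer only a loose guide.

No clear change is therefore expected in this assay, and the estimated step is a 1.2-fold higher number from compound 2 to compound 4 (0.08 log units; within the scatter). The expected value for compound 4 is 7500 nM, with an estimated range from 3500 nM to 15000 nM.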

Compound 4, concentration for 50% growth inhibition: 8270 nM
Beside the measured number, compound 4's estimate is 1.1-fold (0.04 log units) below it, and the stated range covers the measured number.
By their numbers in this assay, from the lowest: compounds 2, 1, 4 and 3 (each within the scatter of the next, the first and the last beyond it).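

In this assay, compound 4 shows that this position takes a chlorine-bearing ring with no clear shift from any earlier compound: the data give a 1.3-fold higher number from compound 2 to compound 4 (0.12 log units; within the scatter), a 1.3-fold higher number from compound 1 to compound 4 (0.10 log units; within the scatter) and a 1.6-fold lower number from compound 3 to compound 4 (0.21 log units; within the scatter). The 3-chlorophenyl group counts 0 hydrogen-bond donors and 0 hydrogen-bond acceptors against 1 of each for 4-hydroxyphenyl, yet this difference comes with no step beyond the scatter, and compound 4 lies within the scatter of both compound 2 and compound 3, which lie beyond the scatter of each other. No supporting evidence is available to account for this result.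

Going by these compounds alone, the single step changes both the group and where it sits, so the effects of chlorine and of its placement cannot be told apart without 4-chlorophenyl. From the compounds shown here alone, it also remains open whether an amine or a carboxylic acid on the ring would give a step beyond the scatter.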